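This account rests on a few compounds, and the source may have more. Where it says the series, first, only, none or still open, it means among the compounds named here.

The measured compounds:

Compound 1, `CC1=C(C(=O)OCC(C)C)C(c2ccco2)NC(=O)N1C`, gives 23% in an assay on membranes from HeLa cells for displacement of a labelled ligand from adenosine receptor A3 (Homo sapiens), read by scintillation counting, with a stated time of 180 min, tested at 1 uM; on this read-out lower numbers stand for less inhibition and higher numbers for more inhibition at the one concentration tested (going by the name of the read-out).
Compound 2, `CC1=C(C(=O)OCC(C)C)C(c2ccoc2)NC(=O)N1C`, gives 16% in this assay.
Compound 3, `CC1=C(c2ncc(C)o2)C(c2ccco2)NC(=O)N1`, gives 4% in this assay.

Compound 1 and compound 2 share one core and differ only in the furan: furan-3-yl in place of furan-2-yl on a saturated ring carbon. The step in this assay is a number 7 percentage points lower from compound 1 to compound 2 (within the scatter), so the two numbers cannot be told apart. Compound 3 sits on a different core; how the two cores differ is not broken down here. Its number is the lowest of the three, and it lies beyond the scatter below both compound 1 and compound 2.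

Compound 4, `CC1=C(c2ncc(C)o2)C(c2ccoc2)NC(=O)N1`, has not yet been measured in this assay. It stands to compound 3 as compound 2 stands to compound 1: furan-3-yl in place of furan-2-yl on a saturated ring carbon. The surroundings of the place are not identical, since in compound 3 the saturated ring carbon is next to the ring atom that bears a 5-methyl-1,3-oxazol-2-yl group, while in compound 1 it is next to the ring atom that bears an isobutoxycarbonyl group and three ring bonds from the ring atom that bears a methyl group, so this is the same kind of change rather than the same change. Among the measured compounds shown here, the only precedent, the step from compound 1 to compound 2, stayed within the scatter, and compound 3 already gives a low number, 4%. Compound 4 is therefore expected to show a step of about a number 1 percentage points lower from compound 3 to compound 4 (within the scatter), resting on a number 7 percentage points lower from compound 1 to compound 2 (within the scatter). The estimate for compound 4 in this assay is 3%, with a likely range from -8% to 15%.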

Compound 4, a percentage reported as inhibition, at one concentration (the size of the read-out at that concentration, not a potency): 1%
Compound 4: the middle estimate sits 2 percentage points above what was measured, within the range that was stated.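

In this assay, putting furan-3-yl in place of furan-2-yl on a saturated ring carbon of the second core gives a number 3 percentage points lower from compound 3 to compound 4 (within the scatter). Set against the earlier step, the change carries over without a detectable difference between the two cores: the same change on two cores in this assay, a number 7 percentage points lower (within the scatter) from compound 1 to compound 2 and a number 3 percentage points lower (within the scatter) from compound 3 to compound 4, 4 percentage points apart, within the scatter of two such steps

Among the compounds shown here, this shows only that the swap did not move the number beyond the usual scatter on either core; it does not show that the two furans are equivalent in general, since the evidence comes from two cores, one concentration and a read-out that is not a potency, and all four numbers are low, so a core with a much higher number might behave differently.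

The compounds shown leave open whether a group other than a furan on that saturated ring carbon, such as a phenyl ring or a thiophene, would shift the number beyond the scatter. They also leave open what a carboxylic acid or a longer ester chain would do in the place held by the isobutoxycarbonyl group or the 5-methyl-1,3-oxazol-2-yl group.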